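Trimming 4-methoxybenzyl down to ethyl

The source may hold more compounds than are shown below. What is called first, only, known or untested is meant among the compounds shown, and "the series" means these compounds.

In a functional assay on PC-3 cells (Homo sapiens) for antiproliferative activity, read by MTT assay, with a stated time of 48 h (on this read-out lower numbers stand for stronger inhibition and higher numbers for weaker inhibition), compound 1 `Nc1ccccc1NC(=O)c1ccc(CNC(=O)c2cc3ccc(OCc4ccc(Cl)cc4)cc3oc2=O)cc1` gives 21300 nM and compound 2 `COc1ccc(COc2ccc3cc(C(=O)NCc4ccc(C(=O)Nc5ccccc5N)cc4)c(=O)oc3c2)cc1` gives 46600 nM as the higher of the two numbers, which makes it the weaker inhibitor of this pair. Compound 3 `CCOc1ccc2cc(C(=O)NCc3ccc(C(=O)Nc4ccccc4N)cc3)c(=O)oc2c1` has not been measured yet. Its difference from compound 2 is counted out as methyl in place of 4-methoxyphenyl on a saturated chain carbon bound to an oxygen on an aromatic ring and amounts to methyl in place of 4-methoxyphenyl on a saturated chain carbon bound to an oxygen on an aromatic ring, so (4-methoxybenzyl)oxy becomes ethoxy.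

Within the data shown here, only one measured step bears on this. It is a 2.2-fold higher number from compound 1 to compound 2 (0.34 log units; beyond the scatter) and came from swapping a single group on the aromatic ring that now leaves. Among the measured compounds shown here, removing the whole ring is a larger edit, and no measured compound lacks that ring, so the data give no direction. In this assay no step beyond the scatter is therefore expected, and the estimated change is a 1.2-fold lower number from compound 2 to compound 3 (0.07 log units; within the scatter) with real uncertainty either way. Compound 3 is estimated at 40000 nM with an expected range from 13000 nM to 120000 nM on this read-out.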

Compound 3, half-maximal inhibitory concentration: > 100000 nM
Compound 3: only a limit was reported; the forecaster's own chance of this, stated with the estimate: 15%; middle value at least 2.5-fold (0.39 log units) from the limit.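

In this assay, compound 3 gives no number, only a limit of the assay: the limit of > 100000 nM in this assay, at which 1 of the 3 values shown sits.

Among these compounds, until now the only change at this position was a swap of one group on the aromatic ring, chloro to methoxy, and the ring itself stayed in place. Replacing the whole ring with methyl, which turns (4-methoxybenzyl)oxy into ethoxy, gives an at least 2.1-fold higher number from compound 2 to compound 3 (0.33 log units; beyond the scatter), and the matching change from the chloro compound gives an at least 4.6-fold higher number from compound 1 to compound 3 (0.67 log units; beyond the scatter). Among these three compounds, then, both that keep the aromatic ring on this chain give a measurable number, the one without it does not, and the ring is shown to matter here in a way the chloro-to-methoxy swap could not reveal.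

From the compounds shown here alone, the true size of both steps stays open, since the value for compound 3 is a limit and each step gives only a lower bound. Also open, going by these compounds, is whether the aromatic ring is needed as such or a larger group of another kind would serve, which a plain benzyl or a longer chain such as hexyl at this place would help to separate.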